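This account rests on a few compounds, and the source may have more. Where it says the series, first, only, none or still open, it means among the compounds named here.

In a functional assay on NCI-H1975 cells (Homo sapiens) for antiproliferative activity, read by MTT assay, with a stated time of 72 h (a higher number here means a weaker inhibitor, a lower number a stronger inhibitor), three compounds have been measured so far. Compound 1 `CC/C=C\C(=O)Nc1cc(Nc2nc(C)cc(-c3cn(C)c4ccccc34)n2)c(OC)cc1N(C)CCN(C)C` gives 1990 nM, and compound 2 `COc1cc(N(C)CCN(C)C)c(NC(=O)/C=C\C(C)C)cc1Nc1nc(C)cc(-c2cn(C)c3ccccc23)n1` gives 1230 nM. These two differ by a single change, (methyl in place of hydrogen on a saturated chain carbon bound to a double-bonded chain carbon and a saturated chain carbon), and that change made a step of a 1.6-fold lower number from compound 1 to compound 2 (0.21 log units; within the scatter). Compound 3 `CC/C=C\C(=O)Nc1cc(Nc2nccc(-c3cn(C)c4ccc(F)cc34)n2)c(OC)cc1N(C)CCN(C)C` is built on a different core; the difference between its core and the core of compound 1 is not broken down here. In this assay compound 3 gives 2600 nM.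

Compound 4 `COc1cc(N(C)CCN(C)C)c(NC(=O)/C=C\C(C)C)cc1Nc1nccc(-c2cn(C)c3ccc(F)cc23)n1` has not yet been measured. For the measured compounds named here, it differs from compound 3 by methyl in place of hydrogen on a saturated chain carbon bound to a double-bonded chain carbon and a saturated chain carbon, which is the same change as the one made from compound 1 to compound 2, at the same place. Resting on the single step of a 1.6-fold lower number from compound 1 to compound 2 (0.21 log units; within the scatter), which stayed within the scatter, the expectation for compound 4 is a step of similar size, a 1.5-fold lower number from compound 3 to compound 4 (0.18 log units; within the scatter). In this assay compound 4 is therefore estimated at 1700 nM, with the likely range running from 800 nM to 3500 nM.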

Compound 4, half-maximal inhibitory concentration: 7360 nM
The estimate for compound 4 lay 4.3-fold (0.64 log units) below the measured number, and the stated range ends below it.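

In this assay, the added methyl that turns but-1-en-1-yl into 3-methylbut-1-en-1-yl gave a 2.8-fold higher number from compound 3 to compound 4 (0.45 log units; beyond the scatter) on the core of compound 3, a real loss of activity on this measure. The two cores clearly do not respond alike to this small change, so the step seen on one core could not simply be carried over to the other: the same change on two cores in this assay, a 1.6-fold lower number (0.21 log units; within the scatter) from compound 1 to compound 2 and a 2.8-fold higher number (0.45 log units; beyond the scatter) from compound 3 to compound 4, 4.6-fold (0.66 log units) apart, beyond the scatter of two such steps. This shows that the outcome of the change depends on the core in these two pairs, but it does not show which feature of the cores is responsible, and two pairs give no general rule for the series.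

The compounds shown leave open which of the differences between the core of compound 1 and the core of compound 3 matters, as they do not separate those differences one at a time. They also leave open how either core would respond to a different group at this place, such as a tert-butyl group, a cyclopropyl ring or an amine.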